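Methoxyphenyl in Place of Dichlorophenyl on a Thiophene Benzamide

The source may report more compounds than this note shows. Statements on the series, on what has been measured and on what is new or still open speak of the compounds shown alone.

Within the data shown here, compound 2 `O=C(N[C@H]1CCN(Cc2ccc(Cl)c(Cl)c2)C1)c1ccc(-c2cccs2)cc1` holds the lower of the two numbers measured so far in an assay on HEK298 cells for displacement of a labelled ligand from D(4) dopamine receptor (Homo sapiens) (a lower number here means a stronger inhibitor, a higher number a weaker inhibitor), where compound 2 gives 15 nM. Its nearest neighbour, compound 1 `O=C(N[C@H]1CCN(Cc2ccc(OC(F)(F)F)cc2)C1)c1cccc(-c2cccs2)c1`, gives 52 nM in this assay, a gap that lies beyond the usual scatter of repeated measurements. Compound 3 `COc1cccc(CN2CC[C@H](NC(=O)c3ccc(-c4cccs4)cc3)C2)c1` has not yet been measured; it differs from compound 2 in one place only: 3-methoxyphenyl in place of 3,4-dichlorophenyl on a saturated chain carbon bound to an amine nitrogen in a ring. Among the measured compounds shown here, no pair of measured compounds shows what this exchange does, so the expectation rests on the value of compound 2 and on a cautious view of how much such a swap may shift the number. In this assay the expected step is a 2.0-fold higher number from compound 2 to compound 3 (0.30 log units; within the scatter), a modest loss that may sit at or just past the edge of the scatter. Compound 3 is therefore expected to give 30 nM in this assay, with a range from 10 nM to 90 nM.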

Compound 3, inhibition constant: 14 nM
For compound 3 the middle estimate is 2.1-fold (0.33 log units) above the measured one; measured number inside the range.
By their numbers in this assay, from the lowest: compounds 3 and 2 (each within the scatter of the next); then compound 1.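

In this assay, 3-methoxyphenyl in place of 3,4-dichlorophenyl on a saturated chain carbon bound to an amine nitrogen in a ring gives a 1.1-fold lower number from compound 2 to compound 3 (0.03 log units; within the scatter), so the two compounds cannot be told apart. Compounds 1 and 2 differ in more than one place and could not show this; the pair now shows that this position accepts a group with no chlorine and with one hydrogen-bond acceptor without a change beyond the scatter. Nothing measured here explains why the two groups read alike. On these data alone, it remains open whether a plain phenyl, a pyridine ring or a phenyl carrying a carboxylic acid would also read alike at this position. As far as these compounds go, it is also open whether the same exchange would read the same on the core of compound 1.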